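This account rests on a few compounds, and the source may have more. Where it says the series, first, only, none or still open, it means among the compounds named here.

In a functional assay on A549 cells (Homo sapiens) for antiproliferative activity, read by MTT assay, with a stated time of 72 h (on this read-out higher numbers stand for weaker inhibition and lower numbers for stronger inhibition), compound 1 `CCCCOC1=C(C(=O)c2ccccc2)C(c2ccc(Br)cc2)N(CCCn2ccnc2)C1=O` gives 18500 nM, and compound 2 `O=C(C1=C(Nc2ccc(Cl)cc2)C(=O)N(CCCn2ccnc2)C1c1ccc(Br)cc1)c1ccccc1` gives 30000 nM. Compound 2 thus stands highest of the two numbers, but only by a 1.6-fold higher number from compound 1 to compound 2 (0.21 log units; within the scatter), so the pair cannot be ordered. Compound 3 `O=C(C1=C(Nc2cccc(Br)c2)C(=O)N(CCCn2ccnc2)C1c1ccc(Br)cc1)c1ccccc1` carries the change (3-bromophenyl in place of 4-chlorophenyl on an amine nitrogen). Among the compounds with values here, no measured step touches the group on this amine nitrogen; the one step known exchanges butoxy for (4-chlorophenyl)amino on a double-bonded ring carbon and itself stays within the scatter, so it gives no direction. Compound 3 is therefore expected to show no movement beyond the scatter, no change at the digits printed from compound 2 to compound 3 (within the scatter), with an estimate of 30000 nM in this assay, ranging from 12000 nM to 75000 nM.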

Compound 3, half-maximal inhibitory concentration: 15800 nM
Compound 3: middle estimate off by 1.9-fold (0.28 log units), on the high side; measured number inside the range.
By their numbers in this assay, from the lowest: compounds 3, 1 and 2 (each within the scatter of the next).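

On the amine nitrogen, 3-bromophenyl in place of 4-chlorophenyl gives a 1.9-fold lower number from compound 2 to compound 3 (0.28 log units; within the scatter) in this assay, so this first reading at the position shows no separation between the two aryl groups. On the double-bonded ring carbon, (3-bromophenyl)amino in place of butoxy gives a 1.2-fold lower number from compound 1 to compound 3 (0.07 log units; within the scatter), so this exchange also shows no separation. No measured evidence bears on these readings. On these data alone, it remains open whether a cyclohexyl group or a longer alkyl chain in place of 3-bromophenyl on the amine nitrogen would move the number beyond the scatter.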